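Benzyl in Place of Methyl on the Selenium of Compound 1

This account rests on a few compounds, and the source may have more. Where it says the series, first, only, none or still open, it means among the compounds named here.

In a functional assay on PC-3 cells (Homo sapiens) for cytotoxicity, read by MTT assay, with a stated time of 72 h (a lower number here means a stronger inhibitor of growth, a higher number a weaker inhibitor of growth), compound 1 `C[Se]/C(=N\C(=O)c1cc2ccccc2s1)NC(=O)c1cc2ccccc2s1` gives 37200 nM. Going by the values given here, compound 2 `O=C(/N=C(/NC(=O)c1ccco1)[Se]Cc1ccccc1)c1ccco1`, in this assay, gives 30500 nM, and its number and that of compound 1 lie within the scatter of each other; the two compounds differ in more than one place, so no single step connects them. Compound 3 `O=C(/N=C(/NC(=O)c1cc2ccccc2s1)[Se]Cc1ccccc1)c1cc2ccccc2s1` carries phenyl in place of hydrogen on a saturated chain carbon bound to a selenium atom relative to compound 1. Among the compounds with values here, no measured step of this kind is at hand, and the expected step of a 1.2-fold lower number from compound 1 to compound 3 (0.09 log units; within the scatter) is one that stays within the scatter, with no clear direction. Compound 3 is therefore estimated at 30000 nM, within 10000 nM to 90000 nM.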

Compound 3, concentration for 50% growth inhibition: 30500 nM
Beside the measured number, compound 3's estimate is 1.0-fold (0.01 log units) below it; low and high end bracket the measured number.
By their numbers in this assay, from the lowest: compounds 2, 3 and 1 (each within the scatter of the next).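

In this assay the first step read at this position, a 1.2-fold lower number from compound 1 to compound 3 (0.09 log units; within the scatter), stays within the scatter. Methyl and benzyl on the core of compound 1 therefore cannot be told apart here, even though a whole phenyl enters on a saturated chain carbon bound to a selenium atom. Nothing at hand speaks to why this change leaves no clear mark. The compounds shown leave open whether a longer chain at this place, or one ending in an amine or a carboxylic acid, would also stay within the scatter.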